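Swapping the Halogenated Phenyl Ester on the Sulfonate

This account rests on a few compounds, and the source may have more. Where it says the series, first, only, none or still open, it means among the compounds named here.

In a functional assay on MCF7 cells (Homo sapiens) for antiproliferative activity, read by sulforhodamine B assay, with a stated time of 48 h (on this read-out higher numbers stand for weaker inhibition and lower numbers for stronger inhibition), compound 1 `CCc1ccccc1OS(=O)(=O)c1ccc(N2CCN(C)C2=O)cc1` gives 26000 nM. Compound 2 `CN1CCN(c2ccc(S(=O)(=O)Oc3cccc(F)c3)cc2)C1=O` reaches only the limit of the assay, > 100000 nM, which is not a number. Compound 3 `CN1CCN(c2ccc(S(=O)(=O)Oc3cccc([N+](=O)[O-])c3)cc2)C1=O` likewise stops at the limit > 100000 nM. The step of an at least 3.8-fold higher number from compound 1 to compound 2 (0.58 log units; beyond the scatter) weakens inhibition, while a step that the two limits leave unreadable from compound 2 to compound 3 cannot be sized, since (the limit of > 100000 nM in this assay, at which 2 of the 3 values shown sit). Compound 4 `CN1CCN(c2ccc(S(=O)(=O)Oc3ccc(Cl)cc3)cc2)C1=O` differs from compound 2 by 4-chlorophenyl in place of 3-fluorophenyl on an oxygen. Among the compounds with values here, no measured step covers this swap directly, and the one step between two halogenated compounds is unreadable. Compound 4 is therefore expected to stay near the limit, with a step of a number no higher from compound 2 to compound 4 (the limit leaves the size open) that is not expected to go beyond the scatter. The estimate for compound 4 in this assay is 100000 nM, within 30000 nM to 300000 nM.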

Compound 4, half-maximal inhibitory concentration: > 100000 nM
Compound 4 gave a limit, no number; the forecaster's own chance of this, stated with the estimate: 65%; the middle value sits exactly at the limit.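

Putting 4-chlorophenyl in place of 2-ethylphenyl on the oxygen bonded to the sulfonyl sulfur gives, in this assay, an at least 3.8-fold higher number from compound 1 to compound 4 (0.58 log units; beyond the scatter). Of the four compounds shown, only compound 1 therefore gives a number, and a second halogen-bearing ring, now with chlorine, has not restored a measurable value. The steps among compound 2, compound 3 and compound 4 cannot be read, so these groups cannot be ranked against each other: the limit of > 100000 nM in this assay, at which 3 of the 4 values shown sit.

On these data alone, it remains open whether a longer chain or an amine on this ring would give a lower number than compound 1.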